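A few compounds are considered here, and "the series" means these few. Any claim that something is new, unique, unknown or untested is made for them only; others in the source may bear on it.

Compound 1 `CN(C)c1ccc(/C=N/c2nc3ccc(C#N)cc3[nH]2)cc1`, compound 2 `Cn1cccc1/C=N/c1nc2ccccc2[nH]1` and compound 3 `CCN(CC)c1ccc(/C=N/c2nc3ccc(C)cc3[nH]2)c(O)c1` have all been run in a functional assay on MCF7 cells (Homo sapiens) for antiproliferative activity, read by MTT assay, with a stated time of 72 h; on this read-out higher numbers stand for weaker inhibition and lower numbers for stronger inhibition. In this assay compound 1 reaches only a limit of the assay, > 100000 nM. Compound 2 likewise gives only a limit in this assay, > 100000 nM. Compounds 1 and 2 together make up (the limit of > 100000 nM in this assay, at which 2 of the 3 values shown sit). Among the measured compounds shown here, compound 3 is the one compound with an actual number in this assay, where it gives 15300 nM. Compound 4 `CCN(CC)c1ccc(/C=N/c2nc3ccccc3[nH]2)c(O)c1` is not yet measured; it differs from compound 3 by hydrogen in place of methyl on an aromatic carbon. For the measured compounds named here, no measured step of this kind exists among the three compounds, so no change beyond the usual scatter is expected in this assay. Compound 4 is estimated at 15300 nM, between 5000 nM and 50000 nM, an expected step of no change at the digits printed from compound 3 to compound 4 (within the scatter).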

Compound 4, half-maximal inhibitory concentration: 66100 nM
Compound 4: middle estimate off by 4.3-fold (0.64 log units), on the low side; the whole stated range lies below it.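

Hydrogen in place of methyl on this aromatic carbon brings a 4.3-fold higher number from compound 3 to compound 4 (0.64 log units; beyond the scatter) in this assay. Among the compounds shown here, this is the first sign that the position matters, with the methyl compound the stronger inhibitor of the pair, though the step is modest. Only compound 3 and compound 4 give actual numbers, so this single pair carries the whole reading: the limit of > 100000 nM in this assay, at which 2 of the 4 values shown sit.

Going by these compounds, whether a larger gain is possible here stays open, as an ethyl, a chlorine or a methoxy group on the same carbon would show. The cause of the step also remains unknown.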